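The source may report more compounds than this note shows. Statements on the series, on what has been measured and on what is new or still open speak of the compounds shown alone.

The set comprises three measured compounds and one that awaits measurement. Compound 1 `Cc1ccc(NC(=O)CSc2nccn2-c2cccc3ccccc23)c(Br)c1` was examined in an ADME assay on MT4 cells (Homo sapiens) for cytotoxicity, read by MTT assay (on this read-out lower numbers stand for higher toxicity in this test and higher numbers for lower toxicity in this test), where compound 1 gives 29400 nM. Compound 2 `Cc1ccc(-n2ccnc2SCC(=O)Nc2ccccc2C)cc1` gives 147000 nM in this assay. Compound 3 `COc1ccc(-n2ccnc2SCC(=O)Nc2ccccc2Br)cc1` was recorded in this assay only as a limit of the assay, > 298000 nM; this is the limit at which one of the three values sits (the limit of > 298000 nM in this assay, at which 1 of the 3 values shown sits). Among the two plain numbers, compound 1 stands lowest, and its nearest neighbour is compound 2, whose number lies beyond the usual scatter above it. Among the measured compounds shown here, no step between two measured compounds differing in a single place is available, so the three measured values stand as separate observations rather than as a series.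

Compound 4 `O=C(CSc1nccn1-c1cccc2ccccc12)Nc1ccccc1[N+](=O)[O-]` differs from compound 1 in one place: 2-nitrophenyl in place of 2-bromo-4-methylphenyl on an amide-type nitrogen. The shared core of compound 1 is otherwise retained. For the measured compounds named here, with no measured step to lean on, the expected change from compound 1 to compound 4 in this assay is a 1.4-fold higher number from compound 1 to compound 4 (0.13 log units; within the scatter), a shift not beyond the scatter. Compound 4 is therefore estimated at 40000 nM, with a range from 12000 nM to 150000 nM.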

Compound 4, half-maximal cytotoxic concentration: 28800 nM
Estimate against measurement, compound 4: 1.4-fold (0.14 log units) above; the range from low to high includes it.
By their numbers in this assay, from the lowest: compounds 4 and 1 (each within the scatter of the next); then compound 2. At a limit, above all of these: compound 3.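

Among the compounds shown here, this is the first step in the set that changes a single place: with 2-nitrophenyl in place of 2-bromo-4-methylphenyl on an amide-type nitrogen, this assay shows a 1.0-fold lower number from compound 1 to compound 4 (0.01 log units; within the scatter). With the shared core retained, the two groups therefore cannot be told apart in this test, although the entering group carries hydrogen-bond acceptors and a double bond outside aromatic rings, while the leaving group has neither, and it alone carries bromine. None of the measurements shown bears on why the two groups read alike.

The compounds shown leave open whether this place tolerates other kinds of substituent equally, for instance a phenyl ring carrying an amine or a carboxylic acid, or a longer chain on the amide-type nitrogen in place of an aromatic ring. Also open, going by these compounds, is whether the same exchange of 2-bromo-4-methylphenyl for 2-nitrophenyl would read alike on a core other than that of compound 1, since this single step is the only one available.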